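The compounds below may be only part of what the source reports. "The series", "measured", "known", "first", "only" and "open" are said of these compounds alone.

Working notes on the series, read in an ADME assay on microsomes from liver (Homo sapiens) for metabolic stability; a higher number here means that the compound lasts longer, a lower number that the compound disappears faster. Among the compounds with values here, compound 2 `COc1ccccc1-c1cc(C2=Nc3c(C(C)(C)C)nn(CCCO)c3C(=O)NC2)ccc1OC` gives 1.37 h and stands at the upper end of the three numbers so far, all of which lie within the scatter of one another: compound 1 `COc1ccc(OC)c(-c2cc(C3=Nc4c(C(C)(C)C)nn(CCCO)c4C(=O)NC3)ccc2OC)c1` gives 1.02 h and compound 3 `COc1ccc(C2=Nc3c(C(C)(C)C)nn(CCCO)c3C(=O)NC2)cc1-c1cnc(N(C)C)cc1C` gives 0.7 h. Compound 4 `COc1ccc(C2=Nc3c(C(C)(C)C)nn(CCCO)c3C(=O)NC2)cc1-c1ccc(C(=O)O)cc1` differs from compound 2 at one place: 4-carboxyphenyl in place of 2-methoxyphenyl on an aromatic carbon. The measured steps that alter the same group bear on this change: a 1.3-fold higher number from compound 1 to compound 2 (0.13 log units; within the scatter) and a 2.0-fold lower number from compound 2 to compound 3 (0.29 log units; within the scatter), and for completeness a 1.5-fold lower number from compound 1 to compound 3 (0.16 log units; within the scatter). All of these fall within the scatter, so no step beyond the scatter is expected here either, although a carboxyphenyl group has not yet been tested in this assay. Compound 4 is expected to give 1.2 h, with a range from 0.6 h to 2.4 h. The expected step is therefore a 1.1-fold lower number from compound 2 to compound 4 (0.06 log units; within the scatter).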

Compound 4, half-life: 2 h
Compound 4: middle estimate off by 1.7-fold (0.22 log units), on the low side; the measured number falls inside the stated range.
By their numbers in this assay, from the lowest: compounds 3, 1, 2 and 4 (each within the scatter of the next, the first and the last beyond it).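

In this assay, within the data shown here, 4-carboxyphenyl gives the first step beyond the scatter at this position, a modest one: a 2.9-fold higher number from compound 3 to compound 4 (0.46 log units; beyond the scatter). Against the methoxyphenyl groups it stays within the scatter, with a 1.5-fold higher number from compound 2 to compound 4 (0.16 log units; within the scatter) and a 2.0-fold higher number from compound 1 to compound 4 (0.29 log units; within the scatter), so the separation holds only against 6-(dimethylamino)-4-methylpyridin-3-yl. Nothing at hand gives a reason for this step.

Still open, as far as these compounds go, is whether the step depends on the carboxylic acid itself or on the phenyl ring that carries it. A methyl ester or a primary amide on that ring would bear on this.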